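The source may report more compounds than this note shows. Statements on the series, on what has been measured and on what is new or still open speak of the compounds shown alone.

Working notes on the series, all read in a functional assay on HT-29 cells (Homo sapiens) for antiproliferative activity, read by MTT assay, with a stated time of 72 h; on this read-out higher numbers stand for weaker inhibition and lower numbers for stronger inhibition. Compound 1 `C=CC(=O)N1CCC(c2ccccc2)CC1` gives > 30000 nM, which is a limit of the assay and not a number. Compound 2 `C=CC(=O)Nc1nc(-c2ccccc2Cl)cs1` gives 10200 nM, and compound 3 `C=CC(=O)Nc1nc(-c2ccc(C)cc2)cs1` gives 16100 nM. These two numbers lie within the scatter of each other, so compound 2 stands level with compound 3 and no order can be drawn between them.

The next compound to be read is compound 4 `C=CC(=O)Nc1nc(-c2ccccc2F)cs1`. It differs from compound 2 in one place: fluoro in place of chloro on an aromatic carbon. This is fluoro in place of chloro on an aromatic carbon of a six-membered aromatic ring of carbon only, ortho to a large group.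

Among the compounds with values here, no measured pair isolates a single change, so there is no direct guide to the size of this step. The nearest hint is that compound 2 at 10200 nM and compound 3 at 16100 nM carry different groups on the aromatic ring, yet their numbers stay within the scatter of each other. In this assay the expected change is therefore small, with a 1.4-fold higher number from compound 2 to compound 4 (0.14 log units; within the scatter) estimated to stay within the scatter and to lean, if anything, towards a slightly higher number. For compound 4 the estimated value is 14000 nM, with an expected range from 7000 nM to 28000 nM.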

Compound 4, half-maximal inhibitory concentration: 18700 nM
Estimate against measurement, compound 4: 1.3-fold (0.13 log units) below; the range from low to high includes it.
By their numbers in this assay, from the lowest: compounds 2, 3 and 4 (each within the scatter of the next). At a limit, above all of these: compound 1.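

In this assay, within the data shown here, fluoro in place of chloro on an aromatic carbon, ortho to a large group, gives the only step that isolates a single change: a 1.8-fold higher number from compound 2 to compound 4 (0.26 log units; within the scatter). At this position, the exchange of one halogen for the other therefore sets no order between the two compounds, and no effect of this change can be claimed from this pair alone. Both compounds give numbers rather than a limit, so the step can be read as a comparison of two measured values, and the only limit among the compounds shown is the following: the limit of > 30000 nM in this assay, at which 1 of the 4 values shown sits.

The compounds shown leave open whether a group of another kind at this position, such as an amine, a carboxylic acid or a methoxy group, would give a number beyond the scatter of the value for compound 2. Among these compounds, they also leave open whether fluoro in place of chloro would read the same on another carbon of the ring, since this one step is the only reading of that change.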